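Working notes on a two-compound series, third compound pending

The source may hold more compounds than are shown below. What is called first, only, known or untested is meant among the compounds shown, and "the series" means these compounds.

Compound 1 `O=c1nc(SCc2ccccc2)nc(SCc2cccc(F)c2)[nH]1`: 4.18%
Compound 2 `N#Cc1ccc(CSc2nc(SCc3ccccc3)nc(=O)[nH]2)cc1`: 1.55%

In an assay for inhibition of Pro-cathepsin H (Homo sapiens), read by fluorescence, tested at 50 uM (a higher number here means more inhibition at the concentration tested (going by the name of the read-out), a lower number less inhibition), both numbers are small. For the measured compounds named here, compound 2 and compound 1 sit within the scatter of each other; the only measured step is a number 2.6 percentage points lower from compound 1 to compound 2 (within the scatter). Compound 3 `CCSc1nc(SCc2ccccc2)nc(=O)[nH]1` carries the change (methyl in place of 4-cyanophenyl on a saturated chain carbon bound to a sulfur). Going by the values given here, the step from compound 1 to compound 2 is the one that bears on it, since it alters the same place, and it stayed within the scatter; no measured step removes the ring itself, so no step beyond the scatter is expected in this assay. Compound 3 is estimated at 3%, range -5% to 12%, an expected step of a number 1.5 percentage points higher from compound 2 to compound 3 (within the scatter).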

Compound 3, a percentage reported as inhibition, at one concentration (the size of the read-out at that concentration, not a potency): -4.06%
For compound 3 the middle estimate is 7.1 percentage points above the measured one, and the stated range covers the measured number.
By their numbers in this assay, from the lowest: compounds 3, 2 and 1 (each within the scatter of the next).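

For the compounds shown here, with the ring gone from this place for the first time, methyl in place of 4-cyanophenyl gives a number 5.6 percentage points lower from compound 2 to compound 3 (within the scatter) in this assay and methyl in place of 3-fluorophenyl gives a number 8.2 percentage points lower from compound 1 to compound 3 (within the scatter). Neither step leaves the scatter, so across these three compounds the aromatic ring on a saturated chain carbon bound to a sulfur shows no measurable contribution. Nothing available accounts for these numbers.

On these data alone, whether a carboxylic acid, an amine or a longer chain at this place would give a step beyond the scatter remains open.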